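Moving the hydroxyl in compound 3 to give compound 4

The compounds below may be only part of what the source reports. "The series", "measured", "known", "first", "only" and "open" are said of these compounds alone.

Of the compounds shown here, three with a shared core have been measured. Compound 3 `Oc1ccc(-c2cc(-c3ccc(Cl)cc3)nc(-c3ccsc3)c2)cc1` gives 47.7% in an assay on isolated protein for inhibition of DNA topoisomerase 1 (Homo sapiens), with a stated time of 30 min, tested at 100 uM (a higher number here means a stronger effect of the compound at the concentration tested, a lower number a weaker effect), the highest of the three numbers. Compound 1 `Oc1cccc(-c2cc(-c3ccc(Cl)cc3)nc(-c3cccs3)c2)c1` gives 15.1% in this assay, and compound 2 `Oc1cccc(-c2cc(-c3ccc(Cl)cc3)nc(-c3cccnc3)c2)c1` gives 2.8% in this assay. Going by the values given here, the only step between compounds that differ in one place is a number 12.3 percentage points lower from compound 1 to compound 2 (beyond the scatter), and it concerns the thiophen-2-yl group, not the hydroxyphenyl group, so it does not bear on the change considered here.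

Compound 4 `Oc1cccc(-c2cc(-c3ccc(Cl)cc3)nc(-c3ccsc3)c2)c1` differs from compound 3 by 3-hydroxyphenyl in place of 4-hydroxyphenyl on an aromatic carbon. Compound 1 and compound 3 differ in two places at once, so their values show only that the pairing of 3-hydroxyphenyl with thiophen-2-yl in compound 1 sits well under the pairing of 4-hydroxyphenyl with thiophen-3-yl in compound 3. Among the compounds with values here, no measured step isolates the position of the hydroxyl. Compound 4 is therefore expected to fall somewhat below compound 3, with the step of a number 15.7 percentage points lower from compound 3 to compound 4 (beyond the scatter) expected to be of modest size and uncertain. Compound 4 is estimated at 32% in this assay, within 12% to 55%.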

Compound 4, a percentage reported as inhibition, at one concentration (the size of the read-out at that concentration, not a potency): 11.7%
Beside the measured number, compound 4's estimate is 20.3 percentage points above it, outside the stated range (below it).
By their numbers in this assay, from the lowest: compounds 2, 4 and 1 (each within the scatter of the next, the first and the last beyond it); then compound 3.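

In this assay, going by these compounds alone, the hydroxyl position is now isolated for the first time: with the rest of the structure held, 3-hydroxyphenyl in place of 4-hydroxyphenyl costs most of the effect (a number 36 percentage points lower from compound 3 to compound 4 (beyond the scatter)). With 3-hydroxyphenyl in place, thiophen-3-yl gives no step beyond the scatter, either against thiophen-2-yl (a number 3.4 percentage points lower from compound 1 to compound 4 (within the scatter)) or against pyridin-3-yl (a number 8.9 percentage points higher from compound 2 to compound 4 (within the scatter)), so thiophen-3-yl alone does not carry the high number of compound 3. Nothing available explains why the position of the hydroxyl matters this much.

On these data alone, whether 4-hydroxyphenyl holds the same advantage alongside thiophen-2-yl or pyridin-3-yl remains open. So does the outcome of replacing the hydroxyl with a methoxy group or an amine at either position.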